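This account rests on a few compounds, and the source may have more. Where it says the series, first, only, none or still open, it means among the compounds named here.

Measured so far:
Compound 1 `COc1ccccc1-c1ncnn1-c1cc(OC)c(OC)c(OC)c1` — in a functional assay on Jurkat cells (Homo sapiens) for antiproliferative activity, read by MTT assay, with a stated time of 72 h (on this read-out higher numbers stand for weaker inhibition and lower numbers for stronger inhibition), compound 1 gives > 10000 nM, which is a limit of the assay rather than a number.
Compound 2 `COc1cc(-c2ncnn2-c2ccc(Cl)c(Cl)c2)cc(OC)c1OC` — in this assay compound 2 gives > 10000 nM, again a limit.
Compound 3 `COc1cc(-c2ncnn2-c2ccc(Cl)cc2Cl)cc(OC)c1OC` — in this assay compound 3 gives > 10000 nM, again a limit.

Compound 1 therefore stands nowhere on a numerical scale: its value in this assay is a limit only, and the same holds for the other two entries, as summed up by the limit of > 10000 nM in this assay, at which 3 of the 3 values shown sit. Going by the values given here, the one single-point step that the set contains, a step that the two limits leave unreadable from compound 2 to compound 3, concerns the dichlorophenyl group on the aromatic nitrogen, not the part of the molecule changed here, and its size cannot be read from two limits.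

Compound 4 `COc1cc(-n2ncnc2-c2ccccc2)cc(OC)c1OC` is not yet measured. It differs from compound 1 by hydrogen in place of methoxy on an aromatic carbon.

Among the compounds with values here, no measured step bears on this change. The three limits give no direction and no size, so nothing is expected of this assay beyond the scatter in either direction, and the most likely outcome is another limit. Compound 4 is estimated at 15000 nM, with a range of 5000 nM to 50000 nM. This estimate means a step that the limit leaves unreadable from compound 1 to compound 4, which is expected only as a placeholder for no readable change.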

Compound 4, half-maximal inhibitory concentration: > 10000 nM
Compound 4 was reported as a limit; the forecaster's own chance of this, stated with the estimate: 85%; the middle value does not contradict the limit.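

No new step can be read between compound 1 and compound 4, as both entries in this assay are limits and not numbers: the limit of > 10000 nM in this assay, at which 4 of the 4 values shown sit.

The compounds shown leave open the size and direction of the change from 2-methoxyphenyl to phenyl, and whether any change to the shared core gives a readable value in this assay.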